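The source may report more compounds than this note shows. Statements on the series, on what has been measured and on what is new or still open speak of the compounds shown alone.

Going by the values given here, in a physicochemical assay for lipophilicity, read by HPLC, at pH 7.5 (on this read-out lower numbers stand for lower lipophilicity and higher numbers for higher lipophilicity), compound 1 `CC[C@@H](Nc1c(C#N)c(-c2ccc(-c3ccccc3F)cc2)nc2cnccc12)C(N)=O` gives 2.7 and compound 2 `CC[C@@H](Nc1c(C#N)c(-c2ccc(-c3cccc(Cl)c3OC)cc2)nc2cnccc12)C(N)=O` gives 3.1 as the higher of the two numbers so far. Compound 3 `CC[C@@H](Nc1c(C#N)c(-c2ccc(-c3cnccc3C)cc2)nc2cnccc12)C(N)=O` has no number yet. It differs from compound 2 at one place, with 4-methylpyridin-3-yl in place of 3-chloro-2-methoxyphenyl on an aromatic carbon. Among the compounds with values here, only one measured step bears on this place: a number 0.40 log units higher from compound 1 to compound 2 (beyond the scatter) with 3-chloro-2-methoxyphenyl in place of 2-fluorophenyl, a modest step beyond the scatter. Within the data shown here, this is thin support, since no measured compound yet has a ring with a hetero atom at this place, and the size of the next step is correspondingly uncertain. With 3-chloro-2-methoxyphenyl leaving, the rise seen in that step is expected to be lost, and the step down is expected to be larger than that rise and beyond the scatter. The estimate is a number 0.90 log units lower from compound 2 to compound 3 (beyond the scatter) in this assay as an expected change. Compound 3 is expected at 2.2 within an estimated range of 1.8 to 2.6 on this read-out.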

Compound 3, distribution coefficient: 2
Beside the measured number, compound 3's estimate is 0.20 log units above it; the range from low to high includes it.
By their numbers in this assay, from the lowest: compound 3; then compound 1; then compound 2.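

Going by these compounds alone, at this position, a ring with a hetero atom now appears for the first time in this assay, and 4-methylpyridin-3-yl in place of 3-chloro-2-methoxyphenyl gives a number 1.10 log units lower from compound 2 to compound 3 (beyond the scatter), a large step in the opposite direction to the modest rise between the two rings of carbon only. Within the data shown here, the fall is not tied to the 3-chloro-2-methoxyphenyl starting point alone, since 4-methylpyridin-3-yl in place of 2-fluorophenyl gives a number 0.70 log units lower from compound 1 to compound 3 (beyond the scatter), so in this set of three the one ring with a hetero atom stands lowest, with no compound against that order, though it rests on compound 3 alone. No measurement here accounts for the size of either step.

The change to compound 3 replaces the ring, its substituents and its atom count together, so the share of the step that belongs to the ring nitrogen, the methyl, or the loss of chlorine and methoxy cannot be separated. As far as these compounds go, it also remains open how the number would move with an unsubstituted pyridinyl ring, or with an amine or a carboxylic acid carried on the ring at this place.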